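The compounds below may be only part of what the source reports. "The series", "measured", "known", "first", "only" and "open" are said of these compounds alone.

Compound 1 `CS/C(=N\C(=O)c1ccno1)NC(=O)c1ccno1` gives > 100000 nM, which is a limit of the assay rather than a number.
Compound 2 `CS/C(=N\C(=O)c1cc2ccccc2s1)NC(=O)c1cc2ccccc2s1` gives 43400 nM.
Compound 3 `O=C(/N=C(/NC(=O)c1ccno1)[Se]Cc1ccccc1)c1ccno1` gives > 100000 nM, which is again a limit of the assay rather than a number.

All three were tested in a functional assay on MCF7 cells (Homo sapiens) for cytotoxicity, read by MTT assay, with a stated time of 72 h; on this read-out higher numbers stand for weaker inhibition of growth and lower numbers for stronger inhibition of growth. Compound 1 and compound 3 share one core, and compound 3 differs from compound 1 in a single place: a group of 8 heavy atoms (7 carbon, 1 selenium; one six-membered aromatic ring of carbon only) in place of a group of 2 heavy atoms (1 carbon, 1 sulfur; no ring), on a carbon with a double bond to nitrogen. The step from compound 1 to compound 3 in this assay, a step that the two limits leave unreadable from compound 1 to compound 3, cannot be read, because the limit of > 100000 nM in this assay, at which 2 of the 3 values shown sit, is where both compounds sit, so the change may have helped, hurt or done nothing. Compound 2 is built on a different core; the difference between the core of compound 1 and the core of compound 2 is not broken down here. Compound 2 is the only one of the three that gives a number in this assay.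

Compound 4 `O=C(/N=C(/NC(=O)c1cc2ccccc2s1)[Se]Cc1ccccc1)c1cc2ccccc2s1` has not yet been measured. For the measured compounds named here, it differs from compound 2 by a group of 8 heavy atoms (7 carbon, 1 selenium; one six-membered aromatic ring of carbon only) in place of a group of 2 heavy atoms (1 carbon, 1 sulfur; no ring), on a carbon with a double bond to nitrogen, which is the same change as the one from compound 1 to compound 3, made at the same place. Since that earlier step gives no readable size, there is no measured guide for what to expect, and the estimate rests mainly on the value of compound 2 itself, 43400 nM, with wide uncertainty. The step from compound 2 to compound 4 is expected to be about a 1.4-fold higher number from compound 2 to compound 4 (0.14 log units; within the scatter). For compound 4 the expected value in this assay is 60000 nM, between 15000 nM and 250000 nM.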

Compound 4, concentration for total growth inhibition: 62900 nM
Estimate against measurement, compound 4: 1.0-fold (0.02 log units) below; measured number inside the range.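

On the core of compound 2, putting the group of 8 heavy atoms, with its selenium and its six-membered aromatic ring, in place of methylsulfanyl gives a 1.4-fold higher number from compound 2 to compound 4 (0.16 log units; within the scatter) in this assay, so on this core the exchange moves the read-out no further than repeated measurements would scatter anyway. For the compounds shown here, this does not show that the change behaves alike on both cores, because the same step from compound 1 to compound 3 cannot be read, with both compounds sitting at a limit of the assay and not at a number: the limit of > 100000 nM in this assay, at which 2 of the 4 values shown sit. One readable step therefore stands alone, with no second step to set beside it, and it describes only the core of compound 2 in this one assay.

The exchange also alters two things at once, the atom on the carbon with a double bond to nitrogen and the group attached to that atom, so the compounds shown leave open what a methylselanyl group, with selenium and no ring, or a benzylsulfanyl group, with the ring and sulfur, would give. Also open, from the compounds shown here alone, is whether an amine or a carboxylic acid on that aromatic ring would move the read-out on either core.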